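This account rests on a few compounds, and the source may have more. Where it says the series, first, only, none or still open, it means among the compounds named here.

Measured in a functional assay on MDA-MB-231 cells (Homo sapiens) for inhibition, read by CCK-8 assay, with a stated time of 48 h; a higher number here means a weaker inhibitor of growth, a lower number a stronger inhibitor of growth:
- Compound 1 `Cc1ccccc1Nc1nc(Nc2ccccc2)ncc1Cl`: > 100000 nM (a limit, not a number)
- Compound 2 `Cc1ccccc1Nc1nc(Nc2ccccn2)ncc1Cl`: 11200 nM

Going by the values given here, compound 2 holds the only true number so far, so its standing rests on a single comparison. Compound 3 `CCN1CCN(c2ccc(Nc3ncc(Cl)c(Nc4ccccc4C)n3)nc2)CC1` adds one group to compound 2: 4-ethylpiperazin-1-yl in place of hydrogen on an aromatic carbon. Among the compounds with values here, the one measured step that bears on this is an at least 8.9-fold lower number from compound 1 to compound 2 (0.95 log units; beyond the scatter), which introduced the pyridin-2-yl group that now takes the addition. Within the data shown here, that step shows this part of the molecule can matter, so a further modest drop is expected, though no measured step tests this group itself. The expected step is a 3.7-fold lower number from compound 2 to compound 3 (0.57 log units; beyond the scatter). Compound 3 is estimated at 3000 nM, with an expected range of 500 nM to 15000 nM.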

Compound 3, concentration for 50% growth inhibition: > 100000 nM
Compound 3: only a limit was reported; the forecaster's own chance of this, stated with the estimate: 5%; middle value at least 33-fold (1.52 log units) away from the limit.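

The pyridin-2-yl ring from the earlier step does not tolerate every addition: 4-ethylpiperazin-1-yl on its aromatic carbon, para to a large group, gives an at least 8.9-fold higher number from compound 2 to compound 3 (0.95 log units; beyond the scatter). What sits on this carbon therefore matters to growth inhibition, and this addition loses the activity that compound 2 showed. The full size of the rise cannot be read, because compound 3 carries only a limit of the assay: the limit of > 100000 nM in this assay, at which 2 of the 3 values shown sit.

As far as these compounds go, whether a simple amine or a methoxy group on this carbon would keep the activity of compound 2 stays open. So does whether the piperazine ring or its ethyl group drives the loss.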